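Working notes: aryl swap from compound 2 to compound 4

The source may report more compounds than this note shows. Statements on the series, on what has been measured and on what is new or still open speak of the compounds shown alone.

- compound 1 `O=C(CSc1nncnc1-c1ccccc1Cl)Nc1ccccc1` 127000 nM
- compound 2 `Cc1ccc(NC(=O)CSc2nncnc2-c2ccccc2Cl)c(Br)c1` 45000 nM
- compound 3 `COC(=O)c1ccc(NC(=O)CSc2nncnc2-c2ccccc2Cl)c(Br)c1` 59000 nM

In an ADME assay on MT4 cells (Homo sapiens) for cytotoxicity, read by MTT assay (on this read-out lower numbers stand for higher toxicity in this test and higher numbers for lower toxicity in this test), compound 2 at 45000 nM stands at the low end of the three numbers. Its nearest neighbour is level within the scatter (a 1.3-fold higher number from compound 2 to compound 3 (0.12 log units; within the scatter)), while the other is clearly apart (a 2.8-fold lower number from compound 1 to compound 2 (0.45 log units; beyond the scatter)).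

Compound 4 `O=C(CSc1nncnc1-c1ccccc1Cl)Nc1ccccc1Cl` is the next to be read, with 2-chlorophenyl in place of 2-bromo-4-methylphenyl on an amide-type nitrogen.

Among the compounds with values here, two measured steps bear on this change. On the same nitrogen, 2-bromo-4-methylphenyl in place of phenyl brought a modest move (a 2.8-fold lower number from compound 1 to compound 2 (0.45 log units; beyond the scatter)). The entering 2-chlorophenyl keeps a halogen on the ring but lacks the methyl. Methoxycarbonyl in place of methyl on an aromatic carbon stayed within the scatter (a 1.3-fold higher number from compound 2 to compound 3 (0.12 log units; within the scatter)). Within the data shown here, no compound here tests the halogen alone or the removal of the methyl alone, so the expectation is a cautious one.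

A small move towards a higher number is expected, smaller than the measured step on this nitrogen, and the estimated step is a 1.4-fold higher number from compound 2 to compound 4 (0.16 log units; within the scatter) in size. In this assay compound 4 is estimated at 65000 nM (expected range 30000 nM to 130000 nM).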

Compound 4, half-maximal cytotoxic concentration: 90000 nM
Estimate against measurement, compound 4: 1.4-fold (0.14 log units) below; low and high end bracket the measured number.
By their numbers in this assay, from the lowest: compounds 2, 3, 4 and 1 (each within the scatter of the next, the first and the last beyond it).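

Chloro in place of hydrogen on an aromatic carbon gives the first read of a lone halogen on the ring at this amide-type nitrogen, and in this assay that change stays within the scatter (a 1.4-fold lower number from compound 1 to compound 4 (0.15 log units; within the scatter)). Replacing 2-bromo-4-methylphenyl with 2-chlorophenyl at the same position also stays within the scatter, though only just (a 2.0-fold higher number from compound 2 to compound 4 (0.30 log units; within the scatter)), so compound 4 is level with both ends of a pair that remains clearly apart (a 2.8-fold lower number from compound 1 to compound 2 (0.45 log units; beyond the scatter)). The measurements shown offer no reason for these numbers.

From the compounds shown here alone, the separate contributions of bromo and methyl remain open, and a ring carrying only one of them on this nitrogen would help separate those contributions from the 2-chlorophenyl result. Also open, going by these compounds, is whether a more different substituent on this ring, such as an amine or a carboxylic acid, would move the number in this assay beyond the scatter from compound 4.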